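Alkoxy versus chloro beside ring nitrogen: cytotoxicity notes

The source may hold more compounds than are shown below. What is called first, only, known or untested is meant among the compounds shown, and "the series" means these compounds.

Measured compounds:
compound 1 `ClCCc1c(Cl)nc2ccc(Cl)cc2c1-c1ccccc1Cl` — > 1400000 nM in an ADME assay on HepG2 2.2.15 cells (Homo sapiens) for cytotoxicity; on this read-out lower numbers stand for higher toxicity in this test and higher numbers for lower toxicity in this test
compound 2 `COc1nc2ccc(Cl)cc2c(-c2ccccc2Cl)c1CCO` — 141000 nM
compound 3 `OCCc1c(Cl)nc2ccc(Cl)cc2c1-c1ccccc1Cl` — 42500 nM

The value of compound 1 in this assay is a limit of the test, not a number. Among the two numbers, compound 3 stands lowest, with compound 2 nearest at a 3.3-fold lower number from compound 2 to compound 3 (0.52 log units; beyond the scatter). The other step, an at least 32-fold lower number from compound 1 to compound 3 (1.51 log units; beyond the scatter), concerns the chain and not the ring position changed here.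

Compound 4 `OCCc1c(OCc2c(Cl)cccc2Cl)nc2ccc(Cl)cc2c1-c1ccccc1Cl` differs from compound 3 by (2,6-dichlorobenzyl)oxy in place of chloro on an aromatic carbon. The step that bears on it is a 3.3-fold lower number from compound 2 to compound 3 (0.52 log units; beyond the scatter), the reverse of which, alkoxy taking the place of chloro on this ring carbon, gave a modest rise in the number. The group entering compound 4 is larger than methoxy, so the transfer is uncertain, and the direction is taken as a modest rise or none beyond the scatter. The expected step is a 1.6-fold higher number from compound 3 to compound 4 (0.22 log units; within the scatter). Compound 4 is therefore estimated at 70000 nM, within 15000 nM to 300000 nM.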

Compound 4, half-maximal cytotoxic concentration: 38500 nM
For compound 4 the middle estimate is 1.8-fold (0.26 log units) above the measured one, within the range that was stated.
By their numbers in this assay, from the lowest: compounds 4 and 3 (each within the scatter of the next); then compound 2. At a limit, above all of these: compound 1.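

In this assay, (2,6-dichlorobenzyl)oxy in place of chloro next to the ring nitrogen gives a 1.1-fold lower number from compound 3 to compound 4 (0.04 log units; within the scatter), so this carbon accepts a much larger group with no change that can be read. An alkoxy group here therefore does not by itself go with the higher number: methoxy compound 2 goes against any such pattern, and the new comparison reads a 3.7-fold lower number from compound 2 to compound 4 (0.56 log units; beyond the scatter) as the 2,6-dichlorophenyl is added. Nothing measured here bears on the cause of these results.

Still open, going by these compounds, is how an unsubstituted benzyloxy group, a longer alkoxy chain or an amine at this carbon would read against methoxy and (2,6-dichlorobenzyl)oxy. Also open, on these data alone, is how 2-chloroethyl in place of 2-hydroxyethyl would read with an alkoxy group at this carbon, since compound 1 gives only a limit of the assay, > 1400000 nM.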